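Swapping Dimethoxyphenyl for Carbamoylphenyl on an Inactive Series

This account rests on a few compounds, and the source may have more. Where it says the series, first, only, none or still open, it means among the compounds named here.

Of the compounds shown here, three share a core and have been tested in an assay on HL-60 cells for agonist activity at N-formyl peptide receptor 3 (Homo sapiens), read by calcium flux; on this read-out higher numbers stand for an effect only at larger amounts of compound and lower numbers for an effect already at smaller amounts. Compound 1 `COc1cccc(Cc2cc(-c3cccs3)nn(CC(=O)Nc3ccc(F)cc3)c2=O)c1` gives only a limit of the assay, > 50000 nM. Compound 2 `Cc1cc(Cc2ccccc2)c(=O)n(CC(=O)Nc2ccc(F)cc2)n1` likewise gives only a limit, > 50000 nM. Compound 3 `COc1cc(Cc2cc(C)nn(CC(=O)Nc3ccc(Br)cc3)c2=O)cc(OC)c1` also gives only a limit in this assay, > 50000 nM. Compound 3 therefore stands exactly where the other two stand: the limit of > 50000 nM in this assay, at which 3 of the 3 values shown sit. Going by the values given here, no measured pair differs in only one place, so no step between measured compounds can be sized.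

Compound 4 `Cc1cc(Cc2ccc(C(N)=O)cc2)c(=O)n(CC(=O)Nc2ccc(Br)cc2)n1` differs from compound 3 in one place: 4-carbamoylphenyl in place of 3,5-dimethoxyphenyl on a saturated chain carbon bound to an aromatic carbon. Since every measured compound, including compound 3 with its limit, sits at the same edge of this assay, there is no evidence that a change of this kind moves activity into the measurable range. The expected step that the limit leaves unreadable from compound 3 to compound 4 is therefore none beyond the scatter, with a fair chance that only a limit is returned again. For compound 4 the estimate in this assay is 60000 nM, expected to fall between 20000 nM and 200000 nM.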

Compound 4, half-maximal effective concentration: > 50000 nM
Compound 4: a limit, no number (the forecaster's own chance of this, stated with the estimate: 85%); the middle value is on the limit's open side.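

Going by these compounds alone, compound 3 and compound 4 both return only a limit, so no step between them can be read: the limit of > 50000 nM in this assay, at which 4 of the 4 values shown sit.

The compounds shown leave open whether any change on this shared core can bring a measurable effect in this assay at all.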